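A few compounds are considered here, and "the series" means these few. Any claim that something is new, unique, unknown or untested is made for them only; others in the source may bear on it.

In a functional assay on HT-1080 cells (Homo sapiens), read by transwell migration, with a stated time of 24 h, tested at 1 uM (on this read-out lower numbers stand for a stronger effect and higher numbers for a weaker effect at the one concentration tested), compound 1 `CCCC(=O)OCc1ccc2oc(=O)c(C(=O)Oc3cccc(Br)c3)cc2c1` gives 50.5%, the lower of the two numbers recorded so far; compound 2 `O=C(Oc1cccc(Cl)c1)c1cc2cc([N+](=O)[O-])ccc2oc1=O` gives 65.8%, a higher number that lies beyond the usual scatter. Compound 3 `NCc1ccc2oc(=O)c(C(=O)Oc3cccc(Br)c3)cc2c1` has not yet been tested. It differs from compound 1 in one place: amino in place of (propylcarbonyl)oxy on a saturated chain carbon bound to an aromatic carbon. Within the data shown here, no pair of measured compounds shows this kind of change, so nothing measured tells in which direction the read-out should move. For compound 3 in this assay a step of a number 1.5 percentage points higher from compound 1 to compound 3 (within the scatter) is expected, not beyond the scatter, giving an estimated 52% within the range 35% to 70%.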

Compound 3, a percentage reported as activity, at one concentration (the size of the read-out at that concentration, not a potency): 79.3%
Compound 3: middle estimate off by 27.3 percentage points, on the low side, and the stated range ends below it.
By their numbers in this assay, from the lowest: compound 1; then compound 2; then compound 3.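

In this assay, putting amino in place of (propylcarbonyl)oxy on a saturated chain carbon bound to an aromatic carbon gives a number 28.8 percentage points higher from compound 1 to compound 3 (beyond the scatter) and so shows that the read-out depends on the group held at this place. Of these two compounds, the weaker effect at the one concentration tested goes with amino. Nothing on hand accounts for this step.

On these data alone, whether a hydroxyl, an acetamide or a longer ester chain at this place would stay near compound 1 or near compound 3 remains open.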